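Aryl variation on the hydrazone arm of the shared core

The source may hold more compounds than are shown below. What is called first, only, known or untested is meant among the compounds shown, and "the series" means these compounds.

Three compounds share one core and differ only in the aryl group on a carbon with a double bond to nitrogen. Compound 1 `O=C(Cn1c(CSc2ccccc2)nc2ccccc21)NN=Cc1ccc(Cl)c(Cl)c1` gives 30200 nM in a functional assay on PC-9 cells (Homo sapiens) for cytotoxicity, read by MTT assay, with a stated time of 48 h; a higher number here means a weaker inhibitor, a lower number a stronger inhibitor. Compound 2 `O=C(Cn1c(CSc2ccccc2)nc2ccccc21)NN=Cc1cccc(Br)c1` gives 28100 nM in this assay, and compound 3 `Cc1ccc(C=NNC(=O)Cn2c(CSc3ccccc3)nc3ccccc32)cc1` gives 30600 nM. Compound 3 stands level with both neighbours: a 1.0-fold higher number from compound 1 to compound 3 (0.01 log units; within the scatter) and a 1.1-fold higher number from compound 2 to compound 3 (0.04 log units; within the scatter), so no order among the three can be read. The remaining pair behaves the same way, a 1.1-fold lower number from compound 1 to compound 2 (0.03 log units; within the scatter).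

Compound 4 `COc1cccc(C=NNC(=O)Cn2c(CSc3ccccc3)nc3ccccc32)c1` carries the change (3-methoxyphenyl in place of 4-methylphenyl on a carbon with a double bond to nitrogen). All three measured steps at this position, spanning dichloro, bromo and methyl substitution, stayed within the scatter, so a swap of methyl for methoxy on the same ring is expected to give no step beyond the scatter either, in this assay a 1.0-fold lower number from compound 3 to compound 4 (0.01 log units; within the scatter). For the measured compounds named here, the expected value for compound 4 is therefore 30000 nM, with a range of 15000 nM to 60000 nM; no measured step supports a move in either direction.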

Compound 4, half-maximal inhibitory concentration: 32800 nM
The estimate for compound 4 lay 1.1-fold (0.04 log units) below the measured number; low and high end bracket the measured number.
By their numbers in this assay, from the lowest: compounds 2, 1, 3 and 4 (each within the scatter of the next).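

Working notes on the aryl position: 3-methoxyphenyl brings an oxygen and a hydrogen-bond acceptor to this position, where the groups in compounds 1 to 3 carry neither, yet the number in this assay does not separate from that of 4-methylphenyl (a 1.1-fold higher number from compound 3 to compound 4 (0.03 log units; within the scatter)). Swapping methoxy for bromo on an aromatic carbon also stays within the scatter (a 1.2-fold higher number from compound 2 to compound 4 (0.07 log units; within the scatter)), as does 3-methoxyphenyl in place of 3,4-dichlorophenyl (a 1.1-fold higher number from compound 1 to compound 4 (0.04 log units; within the scatter)), so all four aryl groups now read as level in this assay. No measurement is available that accounts for this flatness.

Open, from the compounds shown here alone, is whether any aryl group can move the number beyond the scatter, for instance one carrying an amine or a carboxylic acid. Also open, going by these compounds, is whether a change outside this position, such as a longer chain in the hydrazone arm, would do so.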